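The compounds below may be only part of what the source reports. "The series", "measured", "known", "first", "only" and "open" are said of these compounds alone.

In an ADME assay on MIA PaCa-2 cells (Homo sapiens) for cytotoxicity, read by MTT assay, with a stated time of 72 h (a lower number here means a stronger inhibitor, a higher number a weaker inhibitor), compound 1 `COc1ccc(C2=C(c3cc(OC)c(OC)c(OC)c3)C(=O)C(OC(C)=O)C2)cc1OC(C)C` gives > 100 ug/mL as a limit, not a number. Compound 2 `COc1ccc(OC)c(C2=C(c3cc(OC)c(OC)c(OC)c3)C(=O)CC2O[SiH2]C(C)(C)C)c1` gives > 100 ug/mL as a limit too. Compound 3 `COc1ccc(C2=C(c3cc(OC)c(OC)c(OC)c3)C(=O)C(O[SiH2]C(C)(C)C)C2)cc1OC(C)C` gives > 100 ug/mL as a limit as well. The series thus shows the limit of > 100 ug/mL in this assay, at which 3 of the 3 values shown sit, and offers no number to build on.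

Compound 4 `COc1ccc(C2=C(c3cc(OC)c(OC)c(OC)c3)C(=O)C(OC(C)=O)C2)cc1O` differs from compound 1 by hydrogen in place of isopropyl on an oxygen on an aromatic ring and so carries hydroxy where compound 1 carries isopropoxy. For the measured compounds named here, the only measured step that could bear on this is a step that the two limits leave unreadable from compound 1 to compound 3 and it concerns a different place, so it gives no size to carry over. Compound 1 sits at > 100 ug/mL as a limit, so only a move toward a stronger inhibitor could be read in this assay and that direction is expected here, with wide uncertainty. The expected change is an at least 2.5-fold lower number from compound 1 to compound 4 (0.39 log units; beyond the scatter) and it is only a loose estimate. Compound 4 is estimated at 40 ug/mL with a range from 2 ug/mL to 150 ug/mL and may yet stay at the limit.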

Compound 4, half-maximal inhibitory concentration: 18.5 ug/mL
The estimate for compound 4 lay 2.2-fold (0.33 log units) above the measured number, and the stated range covers the measured number.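

In this assay, for the compounds shown here, hydrogen in place of isopropyl on an oxygen on an aromatic ring gives an at least 5.4-fold lower number from compound 1 to compound 4 (0.73 log units; beyond the scatter) and so provides the only readable step. The earlier compounds shown here showed only limits, and the steps among them cannot be read, whereas the change from isopropoxy to hydroxy at this place brings a number out of them. The size of this step remains a bound and not an exact figure, because compound 1 stands at a limit and not at a number: the limit of > 100 ug/mL in this assay, at which 3 of the 4 values shown sit.

The compounds shown leave open whether hydroxy itself is needed at this place or whether removing isopropoxy is enough, and an amine or a fluorine there does not appear among them. As far as these compounds go, it also remains open whether the same change would give a number on the core of compound 3 or of compound 2.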